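Swapping the Naphthalen-1-yl Group in a Level Series

The compounds below may be only part of what the source reports. "The series", "measured", "known", "first", "only" and "open" are said of these compounds alone.

Measured in a functional assay on MCF7 cells (Homo sapiens) for antiproliferative activity, read by MTT assay, with stated times of 24 h and 72 h; on this read-out lower numbers stand for stronger inhibition and higher numbers for weaker inhibition:
Compound 1 `COc1cc([C@@H]2[C@H](Oc3ccccc3)C(=O)N2c2cc(OC)c(OC)c(OC)c2)cc(OC)c1OC`: 29000 nM
Compound 2 `COc1cc(N2C(=O)[C@@H](Oc3ccccc3)[C@H]2c2ccc(Br)cc2)cc(OC)c1OC`: 48000 nM
Compound 3 `COc1cc(N2C(=O)[C@@H](Oc3ccccc3)[C@H]2c2cccc3ccccc23)cc(OC)c1OC`: 53000 nM

These three compounds share one core and differ only in the group on a saturated ring carbon. Compound 3, at 53000 nM, stands level with the other two, since its gaps to them are small: a 1.8-fold higher number from compound 1 to compound 3 (0.26 log units; within the scatter) and a 1.1-fold higher number from compound 2 to compound 3 (0.04 log units; within the scatter). The remaining pair shows the same picture: a 1.7-fold higher number from compound 1 to compound 2 (0.22 log units; within the scatter).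

Compound 4 `COc1cc(N2C(=O)[C@@H](Oc3ccccc3)[C@H]2c2ccc(S(C)(=O)=O)cc2)cc(OC)c1OC` changes the group at that same place, with 4-(methylsulfonyl)phenyl in place of naphthalen-1-yl on a saturated ring carbon. All three measured steps bear on this change, as each swaps one group for another at this position, and none of them stands out from the scatter. Within the data shown here, that is only three compounds, however, and none of them carries a methylsulfonyl group, so the new group remains untested. On this evidence, the step expected in this assay is a 1.2-fold lower number from compound 3 to compound 4 (0.07 log units; within the scatter), with no real change beyond the scatter anticipated. For compound 4 the estimated value is 45000 nM, with an expected range from 18000 nM to 100000 nM.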

Compound 4, half-maximal inhibitory concentration: 62000 nM
Beside the measured number, compound 4's estimate is 1.4-fold (0.14 log units) below it; the range from low to high includes it.
By their numbers in this assay, from the lowest: compounds 1, 2, 3 and 4 (each within the scatter of the next, the first and the last beyond it).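

In this assay, among these compounds, the 4-(methylsulfonyl)phenyl group is the first group at this saturated ring carbon to carry hydrogen-bond acceptors, 2 by the count for the group, against 0 for naphthalen-1-yl, yet compound 4 stays level with its two closest comparators (a 1.2-fold higher number from compound 3 to compound 4 (0.07 log units; within the scatter)) (a 1.3-fold higher number from compound 2 to compound 4 (0.11 log units; within the scatter)). Among the compounds shown here, the same swap at this position also gives the first step in the set to pass beyond the scatter, though only modestly (a 2.1-fold higher number from compound 1 to compound 4 (0.33 log units; beyond the scatter)), so the 3,4,5-trimethoxyphenyl and 4-(methylsulfonyl)phenyl groups can now be told apart, while compounds 2 and 3 remain within the scatter of both compound 1 and compound 4. Nothing available explains this small separation.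

Every group shown at this position is built on an aromatic ring, so it remains open whether a non-aromatic group, such as a cyclohexyl ring or a longer carbon chain, would stay in the same range. Going by these compounds, it is also open whether an amine or a carboxylic acid on the phenyl ring would shift the number, since the groups compared here span only a narrow range of values.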